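The compounds below may be only part of what the source reports. "The series", "measured", "known", "first", "only" and "open" are said of these compounds alone.

The measured compounds in an assay for inhibition of 3-hydroxy-3-methylglutaryl-coenzyme A reductase (Rattus norvegicus) (a higher number here means a weaker inhibitor, a lower number a stronger inhibitor), are three. Compound 1 `Cc1cccc(-c2cc(Cl)cc(Cl)c2/C=C/[C@@H]2C[C@@H](O)CC(=O)O2)c1` gives 16 nM. Compound 2 `O=C1C[C@H](O)C[C@@H](/C=C/c2c(Cl)cc(Cl)cc2-c2ccccc2)O1` gives 80 nM. Compound 3 `Cc1cc(Cl)c(/C=C/[C@@H]2C[C@@H](O)CC(=O)O2)c(-c2ccc(F)c(C)c2)c1` gives 13 nM.

From compound 1 to compound 2 the change is hydrogen in place of methyl on an aromatic carbon and the step is a 5.0-fold higher number from compound 1 to compound 2 (0.70 log units; beyond the scatter). Compound 3 and compound 1 differ in more than one place, and the difference between the two cores is not broken down here. Compound 3 and compound 1 lie within the scatter of each other in this assay, while compound 2 stands beyond the scatter from both.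

Compound 4 `Cc1cc(-c2cccc(Cl)c2/C=C/[C@@H]2C[C@@H](O)CC(=O)O2)ccc1F` is not yet measured. It differs from compound 3 by hydrogen in place of methyl on an aromatic carbon. This is the same kind of change as that from compound 1 to compound 2, though the surroundings differ: in the earlier pair the place is meta to a large group, whereas here it is meta to a 4-fluoro-3-methylphenyl group, meta to a chloro group and para to a large group. Compound 4 is expected to show a step of a 4.6-fold higher number from compound 3 to compound 4 (0.66 log units; beyond the scatter) in this assay, because a 5.0-fold higher number from compound 1 to compound 2 (0.70 log units; beyond the scatter) points that way. Compound 4 is therefore estimated at 60 nM, within 20 nM to 180 nM.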

Compound 4, half-maximal inhibitory concentration: 30 nM
Beside the measured number, compound 4's estimate is 2.0-fold (0.30 log units) above it; low and high end bracket the measured number.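

In this assay, hydrogen in place of methyl on an aromatic carbon again gives a weaker inhibitor, with a 2.3-fold higher number from compound 3 to compound 4 (0.36 log units; beyond the scatter), which matches the direction seen on the core of compound 1. Set side by side, the two steps cannot be told apart, and the change therefore carries from one core to the other in direction and, as far as these data can resolve, in size: the same change on two cores in this assay, a 5.0-fold higher number (0.70 log units; beyond the scatter) from compound 1 to compound 2 and a 2.3-fold higher number (0.36 log units; beyond the scatter) from compound 3 to compound 4, 2.2-fold (0.34 log units) apart, within the scatter of two such steps This rests on just two pairs of compounds: it gives no general rule for the series, says nothing about any third core, and does not explain why the methyl group matters.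

The compounds shown carry only methyl or hydrogen at this place, and it remains open how an ethyl group, a methoxy group or an amine there would read in this assay. Also open, from the compounds shown here alone, is whether the step would hold if the chloro group gave way to a nitrile.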